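The source may hold more compounds than are shown below. What is called first, only, known or untested is meant among the compounds shown, and "the series" means these compounds.

Measured so far:
- compound 1, `CC(C)=CCC/C(C)=C/C[C@]12C[C@@H](CC=C(C)C)C(C)(C)[C@](CC=C(C)C)(C(=O)C(C(=O)c3ccc(O)c(O)c3)=C1O)C2=O`: 5.48 ug/mL
- compound 2, `CC(C)=CCC/C(C)=C/C[C@@H]1C[C@]2(CC=C(C)C)C(=O)[C@@](CC=C(C)C)(C(=O)C(C(=O)c3ccc(O)c(O)c3)=C2O)C1(C)C`: > 20 ug/mL

In a functional assay on SGC-7901 cells (Homo sapiens) for inhibition (a lower number here means a stronger inhibitor, a higher number a weaker inhibitor), compound 1 gives 5.48 ug/mL. For compound 2 only a limit is known: in this assay compound 2 comes out at > 20 ug/mL, a limit of the assay and not a number (the limit of > 20 ug/mL in this assay, at which 1 of the 2 values shown sits). Compound 3, `CC(C)=CC[C@@H]1C[C@]2(CC=C(C)C)C(=O)[C@@](CC=C(C)C)(C(=O)C(C(=O)c3ccc(O)c(O)c3)=C2O)C1(C)C`, is not yet measured. It differs from compound 2 by hydrogen in place of 3-methylbut-2-en-1-yl on a saturated chain carbon bound to a double-bonded chain carbon; read one bond further out, the chain goes from 3,7-dimethylocta-2,6-dien-1-yl to 3-methylbut-2-en-1-yl. With compound 2 at a limit, no direction can be fixed from the numbers. The expected step in this assay is a step that the limit leaves unreadable from compound 2 to compound 3, nothing beyond the scatter. Compound 3 is estimated at 22 ug/mL, between 8 ug/mL and 50 ug/mL, and a limit rather than a number is the likelier outcome.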

Compound 3, half-maximal inhibitory concentration: 13.7 ug/mL
Compound 3: middle estimate off by 1.6-fold (0.21 log units), on the high side; low and high end bracket the measured number.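

In this assay the change to the 3-methylbut-2-en-1-yl chain now reads as a number on one side, with a 2.5-fold higher number from compound 1 to compound 3 (0.40 log units; beyond the scatter). On the other side the change gives an at least 1.4-fold lower number from compound 2 to compound 3 (0.16 log units; that floor lies within the scatter) as a floor only, so the true size of that step stays unfixed. Compound 2 remains a limit of the assay and not a number: the limit of > 20 ug/mL in this assay, at which 1 of the 3 values shown sits.

Still open, going by these compounds, is whether a methyl group, or a chain ending in a carboxylic acid or an amine, would hold the number of compound 3 at this position.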